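A Hydroxyl Added to the Phenylethyl Group

A few compounds are considered here, and "the series" means these few. Any claim that something is new, unique, unknown or untested is made for them only; others in the source may bear on it.

Compound 2 `C[C@@H](Sc1nc2c(cnn2C)c(=O)n1-c1ccccc1)c1ccccc1` and compound 1 `CC(Sc1nc2nn(CC3COC3)cc2c(=O)n1-c1ccccc1)c1ccccc1` share a core in which a sulfur carries a 1-phenylethyl group. Among the measured compounds shown here, in an assay on isolated protein for inhibition of aldehyde dehydrogenase 1A1 (Homo sapiens) (on this read-out higher numbers stand for weaker inhibition and lower numbers for stronger inhibition), compound 2 gives 70 nM, the lowest of the two numbers so far; compound 1 gives 100 nM, which lies within the scatter of the value of compound 2. Compound 3 `CC(Sc1nc2c(cnn2C)c(=O)n1-c1ccccc1)c1cccc(O)c1` differs from compound 2 by a group of 9 heavy atoms (8 carbon, 1 oxygen; one six-membered aromatic ring of carbon only) in place of a group of 8 heavy atoms (8 carbon; one six-membered aromatic ring of carbon only), on a sulfur; the entering group brings one hydrogen-bond donor and one hydrogen-bond acceptor, and the defined stereocentre of compound 2 is absent. For the measured compounds named here, no measured pair shows what such a change does on this core, so the expectation rests on compound 2 alone. The step of a 1.7-fold higher number from compound 2 to compound 3 (0.23 log units; within the scatter) is expected to be small, with no clear direction beyond the scatter. Compound 3 is therefore estimated at 120 nM, with a likely range from 40 nM to 400 nM.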

Compound 3, half-maximal inhibitory concentration: 130 nM
Estimate against measurement, compound 3: 1.1-fold (0.03 log units) below; low and high end bracket the measured number.
By their numbers in this assay, from the lowest: compounds 2, 1 and 3 (each within the scatter of the next).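

On this core, a hydroxyl can be added to the aromatic ring of the group on the sulfur without a clear shift in inhibition: this assay shows a 1.9-fold higher number from compound 2 to compound 3 (0.27 log units; within the scatter) for this change. The same step also gives up the defined stereocentre of compound 2, so one measurement covers two structural differences, and their separate contributions cannot be told apart. No measurement shown offers an explanation for this result.

On these data alone, whether the two mirror-image forms of compound 3 match each other in this assay remains open, and so does the share of the hydroxyl alone in the result. As far as these compounds go, it is also open whether a methoxy group, an amine or a carboxylic acid in place of that hydroxyl would leave the inhibition similarly unchanged.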